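Alkyl to benzyl on the amine nitrogen in a ring

The compounds below may be only part of what the source reports. "The series", "measured", "known", "first", "only" and "open" are said of these compounds alone.

Measured in a functional assay on the whole organism for antagonist activity, with Mus musculus as the target; a higher number here means that more compound is needed for the effect, a lower number that less compound is needed:
compound 1, `CCCN1CCC(C(=O)Nc2cc(Cl)c(N)cc2OC)CC1`: > 10 mg/kg, a limit of the assay, not a number.
compound 2, `CCCCCN1CCC(C(=O)Nc2cc(Cl)c(N)cc2OC)CC1`: > 10 mg/kg, again a limit of the assay, not a number.

Compound 2 therefore stands only at the limit of > 10 mg/kg in this assay, at which 2 of the 2 values shown sit, with no value of its own to place it. For the measured compounds named here, the one measured step, a step that the two limits leave unreadable from compound 1 to compound 2, is unreadable because both ends are limits, so it gives no size and no direction.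

The next compound, compound 3, `COc1cc(N)c(Cl)cc1NC(=O)C1CCN(Cc2ccccc2)CC1`, differs from compound 2 by phenyl in place of butyl on a saturated chain carbon bound to an amine nitrogen in a ring. Going by the values given here, no measured step bears on a phenyl entering at this place, and the unreadable step from compound 1 to compound 2 sets no expectation of size in this assay. The estimate for compound 3 is therefore a guess held near the limit: 8 mg/kg, range 2 mg/kg to 30 mg/kg, meaning an expected step of an at least 1.2-fold lower number from compound 2 to compound 3 (0.09 log units; that floor lies within the scatter) that may well again be reported only as a limit.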

Compound 3, dose for half-maximal effect: 0.5 mg/kg
Beside the measured number, compound 3's estimate is 16-fold (1.20 log units) above it, outside the stated range (below it).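

In this assay, the saturated chain carbon bound to an amine nitrogen in a ring proves to be a place where the group matters, which the alkyl compounds could not show: phenyl in place of butyl gives an at least 20-fold lower number from compound 2 to compound 3 (1.30 log units; beyond the scatter), and phenyl in place of ethyl gives an at least 20-fold lower number from compound 1 to compound 3 (1.30 log units; beyond the scatter). For the compounds shown here, compound 3 is also the first compound with a number rather than a limit, and it gives the series a value to measure later changes against. Compound 1 and compound 2 each stand at a limit, not a number, so both steps give only a floor on the size of the change: the limit of > 10 mg/kg in this assay, at which 2 of the 3 values shown sit.

Still open, on these data alone, is whether the aromatic ring itself carries this change, which cyclohexylmethyl or phenethyl in place of benzyl would test. Also open, as far as these compounds go, is how a chlorine or a methoxy on the phenyl ring would shift the number.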